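Oxazole in place of tetrazole on the benzylic carbon

The source may hold more compounds than are shown below. What is called first, only, known or untested is meant among the compounds shown, and "the series" means these compounds.

Compound 1 `CCCCOC(=O)NS(=O)(=O)c1sc(CC(C)C)cc1-c1ccc(Cc2nccs2)cc1`: 3.2 nM
Compound 2 `CCCCOC(=O)NS(=O)(=O)c1sc(CC(C)C)cc1-c1ccc(Cn2ncnn2)cc1`: 16 nM

Within the data shown here, in an assay on membranes from uterus for displacement of a labelled ligand from Angiotensin type II receptor (Sus scrofa), with a stated time of 1.5 h (on this read-out higher numbers stand for weaker inhibition and lower numbers for stronger inhibition), compound 2 gives the higher of the two numbers, and its only neighbour is compound 1, whose number is lower by a 5.0-fold higher number from compound 1 to compound 2 (0.70 log units; beyond the scatter). Compound 3 `CCCCOC(=O)NS(=O)(=O)c1sc(CC(C)C)cc1-c1ccc(Cc2ncco2)cc1` carries 1,3-oxazol-2-yl in place of 2H-tetrazol-2-yl on a saturated chain carbon bound to an aromatic carbon. Among the measured compounds shown here, the one step that bears on this, from compound 1 to compound 2, moved the read-out when a 1,3-thiazol-2-yl gave way to the tetrazole. For compound 3 the change is expected to run the other way, a step of a 3.2-fold lower number from compound 2 to compound 3 (0.51 log units; beyond the scatter) in this assay. Compound 3 is therefore estimated at 5 nM, within 2 nM to 13 nM.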

Compound 3, inhibition constant: 3.9 nM
Estimate against measurement, compound 3: 1.3-fold (0.11 log units) above; the measured number falls inside the stated range.
By their numbers in this assay, from the lowest: compounds 1 and 3 (each within the scatter of the next); then compound 2.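

In this assay, 1,3-oxazol-2-yl on the saturated chain carbon bound to an aromatic carbon recovers what the tetrazole lost (a 4.1-fold lower number from compound 2 to compound 3 (0.61 log units; beyond the scatter)). The two rings with two hetero atoms cannot be told apart in this read-out (a 1.2-fold higher number from compound 1 to compound 3 (0.09 log units; within the scatter)), so among these three compounds only the 2H-tetrazol-2-yl of compound 2 stands apart, and sulfur or oxygen in the ring makes no measurable difference. No evidence is available to explain this. As far as these compounds go, whether an amine or a carboxylic acid at the same place would keep the lower numbers of compound 1 and compound 3 remains open.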